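The compounds below may be only part of what the source reports. "The series", "measured", "known", "first", "only" and "open" are said of these compounds alone.

Measured in a functional assay on MCF7 cells (Homo sapiens) for inhibition, read by MTT assay, with a stated time of 4 days; on this read-out higher numbers stand for an effect only at larger amounts of compound and lower numbers for an effect already at smaller amounts:
- compound 1 `CC(C)Cn1c(=O)n(C)c(=O)c2nc(SCCCCO)c(Cc3cccc4ccccc34)nc21`: 516 nM
- compound 2 `CC(C)Cn1c(=O)n(C)c(=O)c2nc(CCCCCO)c(Cc3cccc4ccccc34)nc21`: 570 nM

Going by the values given here, compound 2 stands level with compound 1, the only other measured compound; the single measured step is a 1.1-fold higher number from compound 1 to compound 2 (0.04 log units; within the scatter). Next comes compound 3 `CC(C)Cn1c(=O)n(C)c(=O)c2nc(/C=C\CCCO)c(Cc3cccc4ccccc34)nc21`, which carries 5-hydroxypent-1-en-1-yl in place of 5-hydroxypentyl on the same aromatic carbon: 5-hydroxypent-1-en-1-yl in place of 5-hydroxypentyl on an aromatic carbon. Among the compounds with values here, the one measured step bearing on this changed the chain at that same carbon and gave a 1.1-fold higher number from compound 1 to compound 2 (0.04 log units; within the scatter), so no shift beyond the scatter is expected in this assay. The expected step is a 1.0-fold lower number from compound 2 to compound 3 (0.02 log units; within the scatter). Compound 3 is estimated at 550 nM, with an expected range of 250 nM to 1200 nM.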

Compound 3, half-maximal effective concentration: 439 nM
Estimate against measurement, compound 3: 1.3-fold (0.10 log units) above; the range from low to high includes it.
By their numbers in this assay, from the lowest: compounds 3, 1 and 2 (each within the scatter of the next).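

In this assay, the double bond of 5-hydroxypent-1-en-1-yl brings no shift beyond the scatter at this aromatic carbon (a 1.3-fold lower number from compound 2 to compound 3 (0.11 log units; within the scatter)). The comparison with (4-hydroxybutyl)sulfanyl also stays within the scatter (a 1.2-fold lower number from compound 1 to compound 3 (0.07 log units; within the scatter)), so all three chains read alike at this position. No supporting data bear on this result. Open, going by these compounds, is whether an amine or a carboxylic acid in place of the terminal hydroxyl would shift the number. A longer chain at this carbon also remains untested among the compounds shown.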